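Amino for Hydroxy: One Step Carried to a Second Core

The source may report more compounds than this note shows. Statements on the series, on what has been measured and on what is new or still open speak of the compounds shown alone.

Measured compounds:
compound 1, `COc1ccc(-c2ssc(=S)c2-c2cc(OC)c(OC)c(OC)c2)cc1O`, 231 nM
compound 2, `COc1ccc(-c2ssc(=S)c2-c2cc(OC)c(OC)c(OC)c2)cc1N`, 834 nM
compound 3, `COc1ccc(-c2ss/c(=N/O)c2-c2cc(OC)c(OC)c(OC)c2)cc1O`, 730 nM

All three values come from a functional assay on HT-1080 cells (Homo sapiens) for antiproliferative activity, read by MTT assay, with a stated time of 72 h; on this read-out higher numbers stand for weaker inhibition and lower numbers for stronger inhibition. Compound 1 and compound 2 differ by one change, (amino in place of hydroxy on an aromatic carbon), and that change made a 3.6-fold higher number from compound 1 to compound 2 (0.56 log units; beyond the scatter). Compound 3 has a different core from compound 1; the difference between the two cores is not broken down here. Among the compounds with values here, compound 4, `COc1ccc(-c2ss/c(=N/O)c2-c2cc(OC)c(OC)c(OC)c2)cc1N`, is not yet measured and is related to compound 3 by amino in place of hydroxy on an aromatic carbon, the same change, at the same place, as the one between compound 1 and compound 2. Because compound 2 gave 834 nM against compound 1 at 231 nM, the expectation for compound 4 is a step of similar size, a 3.0-fold higher number from compound 3 to compound 4 (0.48 log units; beyond the scatter), which rests on that single earlier pair only. The estimate for compound 4 in this assay is 2200 nM, expected to lie between 900 nM and 5500 nM.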

Compound 4, half-maximal inhibitory concentration: 9360 nM
Compound 4: the middle estimate sits 4.3-fold (0.63 log units) below what was measured, outside the stated range (above it).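

On the second core, amino in place of hydroxy gave a 13-fold higher number from compound 3 to compound 4 (1.11 log units; beyond the scatter) and so moved the number the same way as on the first core, but further. The direction of the step carried from one core to the other, while its size did not: the same change on two cores in this assay, a 3.6-fold higher number (0.56 log units; beyond the scatter) from compound 1 to compound 2 and a 13-fold higher number (1.11 log units; beyond the scatter) from compound 3 to compound 4, 3.6-fold (0.55 log units) apart, beyond the scatter of two such steps. Within the data shown here, these two pairs show only that the step differed between these two cores; they do not show which part of the core accounts for the gap, or how the change would behave on a further core.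

The compounds shown leave open whether another group in this place, such as methylamino or acetamide, would separate the two cores in the same way. They also leave open whether a fluorine atom there would do so.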